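This account rests on a few compounds, and the source may have more. Where it says the series, first, only, none or still open, it means among the compounds named here.

Measured compounds:
compound 1 `Nc1c(C(=O)NC2CCCC2)oc2nc(-c3ccccc3)cc(C(F)(F)F)c12` — in a functional assay on HepG2 cells (Homo sapiens) for antiproliferative activity, read by MTT assay (on this read-out lower numbers stand for stronger inhibition and higher numbers for weaker inhibition), compound 1 gives 32400 nM
compound 2 `Nc1c(C(=O)N/N=C/c2ccccc2)oc2nc(-c3ccccc3)cc(C(F)(F)F)c12` — in this assay compound 2 gives 13100 nM
compound 3 `CNC(=O)c1oc2nc(-c3ccccc3)cc(C(F)(F)F)c2c1N` — in this assay compound 3 gives 41200 nM

Compound 3 stands at the highest number of the three. Against compound 1 it sits within the scatter, the step being a 1.3-fold higher number from compound 1 to compound 3 (0.10 log units; within the scatter), so no order between these two can be read. Against compound 2 the gap is real, the step being a 3.1-fold higher number from compound 2 to compound 3 (0.50 log units; beyond the scatter).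

Compound 4 `Cc1ccc(/C=N/NC(=O)c2oc3nc(-c4ccccc4)cc(C(F)(F)F)c3c2N)cc1` is the next member of the series. It differs from compound 3 in one place: a group of 9 heavy atoms (8 carbon, 1 nitrogen; one six-membered aromatic ring of carbon only) in place of one carbon atom, on an amide-type nitrogen. The change closely mirrors the measured pair, since the step of a 3.1-fold higher number from compound 2 to compound 3 (0.50 log units; beyond the scatter) runs in the opposite direction across an almost identical replacement, and the step of a 2.5-fold lower number from compound 1 to compound 2 (0.39 log units; beyond the scatter) shows the same benzylidene hydrazide group again linked to a lower number. Both measured steps therefore bear on the change from compound 3 to compound 4 and point the same way, toward a lower number in this assay of modest size.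

Compound 4 is accordingly expected to return about 12000 nM in this assay, within a range of 5000 nM to 30000 nM. The expected step is a 3.4-fold lower number from compound 3 to compound 4 (0.54 log units; beyond the scatter), an estimate resting on the value of compound 2, 13100 nM.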

Compound 4, half-maximal inhibitory concentration: 8900 nM
Compound 4: middle estimate off by 1.3-fold (0.13 log units), on the high side, within the range that was stated.
By their numbers in this assay, from the lowest: compounds 4 and 2 (each within the scatter of the next); then compounds 1 and 3 (each within the scatter of the next).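

On the amide-type nitrogen, putting the group of 9 heavy atoms in place of methyl gives a 4.6-fold lower number from compound 3 to compound 4 (0.67 log units; beyond the scatter) in this assay, and putting it in place of cyclopentyl gives a 3.6-fold lower number from compound 1 to compound 4 (0.56 log units; beyond the scatter), so the lower number seen earlier with the group of 8 heavy atoms now recurs in a second member of the series. The earlier compounds shown here included no change within that group itself, and methyl in place of hydrogen on an aromatic carbon gives a 1.5-fold lower number from compound 2 to compound 4 (0.17 log units; within the scatter), so no order can be read between these two compounds. Both members carrying a six-membered aromatic ring in this group therefore stand apart from the methyl and cyclopentyl amides, and the added methyl makes no readable difference.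

Nothing available here accounts for the lower numbers seen with these groups. The compounds shown leave open whether a chlorine, methoxy or carboxylic acid on the aromatic ring would move the number beyond the scatter, and whether a plain benzyl group on the amide-type nitrogen, lacking the nitrogen and the double bond of the present group, would keep the lower number.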